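This account rests on a few compounds, and the source may have more. Where it says the series, first, only, none or still open, it means among the compounds named here.

Working notes on the series. In a functional assay on MCF7 cells (Homo sapiens) for antiproliferative activity, read by MTT assay, with a stated time of 72 h (on this read-out lower numbers stand for stronger inhibition and higher numbers for weaker inhibition), compound 3 `CC(C)=CC(=O)Nc1cccc(Oc2nc(Nc3ccn(C)n3)nc3c2CSCC3)c1` gives > 50000 nM, which is a limit and not a number. Compound 1 `C=CC(=O)Nc1cccc(Oc2nc(Nc3ccn(C)n3)nc3c2CSCC3)c1` gives > 50000 nM, also a limit. Together they make up (the limit of > 50000 nM in this assay, at which 2 of the 3 values shown sit). Among the measured compounds shown here, the only number so far comes from compound 2 `C/C=C/C(=O)Nc1cccc(Oc2nc(Nc3ccn(C)n3)nc3c2CSCC3)c1`, at 40000 nM.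

Compound 4 `CC(C)/C=C/C(=O)Nc1cccc(Oc2nc(Nc3ccn(C)n3)nc3c2CSCC3)c1` has 3-methylbut-1-en-1-yl in place of 2-methylprop-1-en-1-yl on a carbonyl carbon.

Three measured steps change the same group on that carbonyl carbon. They are an at least 1.2-fold lower number from compound 1 to compound 2 (0.09 log units; that floor lies within the scatter), an at least 1.2-fold higher number from compound 2 to compound 3 (0.09 log units; that floor lies within the scatter) and a step that the two limits leave unreadable from compound 1 to compound 3. None of them shows a change beyond the scatter, although the limits leave their true sizes open. Given > 50000 nM for compound 3, no step beyond the scatter is expected in this assay, and a further limit is the likeliest result.

The expected step is a step that the limit leaves unreadable from compound 3 to compound 4.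

Compound 4 is estimated at 55000 nM, with an expected range of 30000 nM to 100000 nM.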

Compound 4, half-maximal inhibitory concentration: > 50000 nM
Compound 4: a limit, no number (the forecaster's own chance of this, stated with the estimate: 70%); the middle value lies beyond the limit too.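

The 3-methylbut-1-en-1-yl group extends the set of groups on this carbonyl carbon to a larger, five-carbon chain, yet in this assay that change still yields no number, and the limit gains another member: the limit of > 50000 nM in this assay, at which 3 of the 4 values shown sit.
Among the compounds shown here, the one readable new step is an at least 1.2-fold higher number from compound 2 to compound 4 (0.09 log units; that floor lies within the scatter), so the only compound with a number, compound 2, is still not separated from compound 4 by a change beyond the scatter. The steps from compound 1 and from compound 3 to compound 4 cannot be read, as both ends of each are limits.

On these data alone, how far the compounds at the limit differ from one another remains unknown. As far as these compounds go, it also remains open whether an amine on the end of the chain, or a carboxylic acid there, would give a value clear of the limit.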